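Benzyl Ester to Free Acid on the Shared Core

This account rests on a few compounds, and the source may have more. Where it says the series, first, only, none or still open, it means among the compounds named here.

Of the compounds shown here, three built on one shared core have been measured in a functional assay on the whole organism (Tail, strain ICR) with Mus musculus as the target, in the tail flick test, with a stated time of 90 min, at a dose of 25 umol/kg by the oral route; on this read-out lower numbers stand for a weaker effect and higher numbers for a stronger effect at the one dose given. Compound 1 `O=C(CN(c1nc(Cl)nc2[nH]cnc12)C1CC1)N[C@@H](CO)C(=O)OCc1ccccc1` gives 34.5%, the highest of the three numbers. Compound 2 `C[C@@H](O)[C@H](NC(=O)CN(c1nc(Cl)nc2[nH]cnc12)C1CC1)C(=O)OCc1ccccc1` gives 29.9%, and compound 3 `O=C(CN(c1nc(Cl)nc2[nH]cnc12)C1CC1)N[C@@H](CC(=O)OCc1ccccc1)C(=O)OCc1ccccc1` gives 15.6%. The step of a number 4.6 percentage points lower from compound 1 to compound 2 (within the scatter) stays within the scatter, whereas a number 18.9 percentage points lower from compound 1 to compound 3 (beyond the scatter) and a number 14.3 percentage points lower from compound 2 to compound 3 (beyond the scatter) are modest falls beyond it.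

Compound 4 `O=C(CN(c1nc(Cl)nc2[nH]cnc12)C1CC1)N[C@@H](CO)C(=O)O` has not yet been measured in this assay. It differs from compound 1 by hydrogen in place of benzyl on an oxygen next to a carbonyl group; cut one bond further out, the change reads benzyloxycarbonyl to carboxy. Within the data shown here, no measured step removes a benzyl group from such an oxygen, so nothing bears on this change directly. The two steps that touch a benzyloxycarbonyl group at all, a number 18.9 percentage points lower from compound 1 to compound 3 (beyond the scatter) and a number 14.3 percentage points lower from compound 2 to compound 3 (beyond the scatter), add one at a different place and lower the read-out modestly; they cannot fix the direction here. One therefore expects at most a modest step, more likely downward than upward, and the expected step is a number 9.5 percentage points lower from compound 1 to compound 4 (within the scatter). For compound 4 the estimated value in this assay is 25%, within a range from 10% to 42%.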

Compound 4, a percentage reported as activity, at one dose (the size of the read-out at that dose, not a potency): 43.9%
For compound 4 the middle estimate is 18.9 percentage points below the measured one, outside the stated range (above it).
By their numbers in this assay, from the lowest: compound 3; then compounds 2, 1 and 4 (each within the scatter of the next, the first and the last beyond it).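

In this assay, hydrogen in place of benzyl on an oxygen next to a carbonyl group gives a number 9.4 percentage points higher from compound 1 to compound 4 (within the scatter), so no change can be read from this step. Among these compounds, the earlier steps all changed the side chain elsewhere and left the benzyloxycarbonyl group at this place untouched, so this is the first view of the place itself: at the one dose given, the read-out does not depend on the benzyl group, and with it the six-membered aromatic ring of carbon only, being present on this oxygen. Nothing measured alongside this result accounts for it, and the read-out alone cannot say what happens to either compound in the animal.

The compounds shown leave open whether the same change from benzyloxycarbonyl to carboxy would also leave the read-out in place on the side chains of compound 2 and compound 3. They also leave open how a smaller ester such as a methyl ester, or a primary amide in place of the carboxy group, would read at this place, and whether any of these compounds would separate at another dose.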